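Methyl to Methoxy in an Antiproliferative Series

The compounds below may be only part of what the source reports. "The series", "measured", "known", "first", "only" and "open" are said of these compounds alone.

In a functional assay on MCF7 cells (Homo sapiens) for antiproliferative activity, read by MTT assay, with a stated time of 48 h (on this read-out higher numbers stand for weaker inhibition and lower numbers for stronger inhibition), compound 1 (`N=C(N)N/N=C(/C=C/c1ccccc1)c1ccc(Cl)cc1`) gives 350 nM, while compound 2 (`Cc1ccc(C(/C=C/c2ccccc2)=N\NC(=N)N)cc1`) gives 14000 nM, the higher, weaker of the two numbers. Compound 3 (`COc1ccc(C(/C=C/c2ccccc2)=N\NC(=N)N)cc1`) is still unmeasured and carries methoxy in place of methyl on an aromatic carbon. Among the measured compounds shown here, the only measured step at this place, a 40-fold higher number from compound 1 to compound 2 (1.60 log units; beyond the scatter), is large and shows that a swap here can matter. One step cannot fix a direction, but a moderate move to a lower number in this assay is expected, namely a 2.8-fold lower number from compound 2 to compound 3 (0.45 log units; beyond the scatter). The estimated value for compound 3 is 5000 nM, within 1000 nM to 20000 nM.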

Compound 3, half-maximal inhibitory concentration: 13000 nM
Compound 3: middle estimate off by 2.6-fold (0.41 log units), on the low side; measured number inside the range.
By their numbers in this assay, from the lowest: compound 1; then compounds 3 and 2 (each within the scatter of the next).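

In this assay, swapping methyl for methoxy at this position makes no clear difference: a 1.1-fold lower number from compound 2 to compound 3 (0.03 log units; within the scatter) stays within the scatter. Chloro stands apart among these three groups, with a 37-fold higher number from compound 1 to compound 3 (1.57 log units; beyond the scatter) as a large step beyond the scatter, so the earlier large step was not a general effect of replacing chloro with just any group's neighbour in size or kind, at least not among these two. No measured evidence here explains this pattern. The compounds shown leave open whether bromo, fluoro or trifluoromethyl on the same carbon would match chloro. An amine there could fall on either side.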